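Removing the Halogen From the Pendant Phenyl Ring

A few compounds are considered here, and "the series" means these few. Any claim that something is new, unique, unknown or untested is made for them only; others in the source may bear on it.

Compound 2 `O=C(Nc1ccc(Oc2ncnc3ccsc23)c(F)c1)c1nn(-c2ccc(Br)cc2)ccc1=O` and compound 1 `O=C(Nc1ccc(Oc2ncnc3ccsc23)c(F)c1)c1nn(-c2ccc(F)cc2)ccc1=O` share one core and differ only in the halogen carried on the pendant phenyl ring. In a functional assay on MCF7 cells (Homo sapiens) for cytotoxicity, read by MTT assay, with a stated time of 72 h (on this read-out lower numbers stand for stronger inhibition and higher numbers for weaker inhibition), compound 1 gives 5720 nM, and in the same test compound 2 gives 9620 nM. For the measured compounds named here, compound 2 thus holds the higher of the two numbers measured so far, yet the step of a 1.7-fold higher number from compound 1 to compound 2 (0.23 log units; within the scatter) stays within the scatter, so the two compounds cannot be told apart on this evidence. Compound 3 `O=C(Nc1ccc(Oc2ncnc3ccsc23)c(F)c1)c1nn(-c2ccccc2)ccc1=O` has not been measured yet. Its change from compound 2 is hydrogen in place of bromo on an aromatic carbon. Going by the values given here, the only measured step that bears on this change, a 1.7-fold higher number from compound 1 to compound 2 (0.23 log units; within the scatter), did not move the number beyond the scatter, and nothing in the data suggests that taking the halogen away altogether should act differently. The expectation is therefore a step of no more than the scatter, a 1.3-fold lower number from compound 2 to compound 3 (0.11 log units; within the scatter), in this assay. Compound 3 is estimated at 7500 nM, with a likely range from 3000 nM to 18000 nM.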

Compound 3, half-maximal inhibitory concentration: 12400 nM
Compound 3: the middle estimate sits 1.7-fold (0.22 log units) below what was measured; the measured number falls inside the stated range.
By their numbers in this assay, from the lowest: compounds 1, 2 and 3 (each within the scatter of the next, the first and the last beyond it).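

In this assay the change from 4-bromophenyl to phenyl gives a 1.3-fold higher number from compound 2 to compound 3 (0.11 log units; within the scatter) and so, on this aromatic carbon para to a large group, hydrogen and bromo cannot be told apart. For the compounds shown here, the change from fluoro to hydrogen at the same place gives a 2.2-fold higher number from compound 1 to compound 3 (0.34 log units; beyond the scatter) and is the first step at this position to pass the scatter, although it is modest and compound 2 lies within the scatter of both compound 1 and compound 3, so only the two ends of this short series can be separated. No measured evidence accompanies these numbers to explain the gap between the fluoro and hydrogen compounds.

The compounds shown leave open whether a group other than a halogen or hydrogen at this place, such as an amine, a carboxylic acid or a methoxy group, would shift the number further in either direction. They also leave open whether chloro, the halogen missing from this set, would fall with fluoro, with bromo or somewhere else among these closely spaced values.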